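Aryl exchange on the shared core, compound 1 to compound 4

The compounds below may be only part of what the source reports. "The series", "measured", "known", "first", "only" and "open" are said of these compounds alone.

Compound 1 `O=C(O)CN1C(=O)/C(=C/c2nc3ccccc3n2Cc2ccc(F)cc2)SC1=S` gives 1420 nM in a functional assay on HL-60 cells (Homo sapiens) for cytotoxicity, read by MTT assay, with a stated time of 48 h (on this read-out higher numbers stand for weaker inhibition and lower numbers for stronger inhibition), the lowest of the three numbers here. Compound 3 `O=C(O)CN1C(=O)/C(=C/c2nc3ccccc3n2Cc2ccc(F)c(F)c2)SC1=S` gives 2740 nM, and compound 2 `O=C(O)CN1C(=O)/C(=C/c2nc3ccccc3n2Cc2ccc(C(F)(F)F)cc2)SC1=S` gives 3560 nM; the step of a 1.9-fold higher number from compound 1 to compound 3 (0.29 log units; within the scatter) stays within the scatter, whereas a 2.5-fold higher number from compound 1 to compound 2 (0.40 log units; beyond the scatter) lies beyond it. Compound 4 `COc1cc(Cn2c(/C=C3\SC(=S)N(CC(=O)O)C3=O)nc3ccccc32)cc(OC)c1` differs from compound 1 by 3,5-dimethoxyphenyl in place of 4-fluorophenyl on a saturated chain carbon bound to an aromatic nitrogen. Both measured departures from the 4-fluorophenyl of compound 1 gave higher numbers, the larger change the larger rise. The exchange to 3,5-dimethoxyphenyl is a larger change still. For compound 4 a modest rise beyond the scatter is therefore expected, a 2.1-fold higher number from compound 1 to compound 4 (0.32 log units; beyond the scatter). For compound 4 the expected value is 3000 nM, with a range from 1000 nM to 9000 nM.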

Compound 4, half-maximal inhibitory concentration: 1410 nM
Compound 4: middle estimate off by 2.1-fold (0.33 log units), on the high side; the measured number falls inside the stated range.
By their numbers in this assay, from the lowest: compounds 4, 1, 3 and 2 (each within the scatter of the next, the first and the last beyond it).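

In this assay, for the compounds shown here, the saturated chain carbon bound to an aromatic nitrogen carries 3,5-dimethoxyphenyl with no loss against 4-fluorophenyl (a 1.0-fold lower number from compound 1 to compound 4 (0.00 log units; within the scatter)) or against 3,4-difluorophenyl (a 1.9-fold lower number from compound 3 to compound 4 (0.29 log units; within the scatter)), and only the step from 4-(trifluoromethyl)phenyl lies beyond the scatter (a 2.5-fold lower number from compound 2 to compound 4 (0.40 log units; beyond the scatter)). Compound 4 therefore goes against the reading that a larger aryl exchange brings a higher number, a reading that compound 2 and compound 3 alone had allowed. No measurement here accounts for this tolerance.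

From the compounds shown here alone, whether an aryl group is needed at this carbon stays open. An amine or a longer alkyl chain in its place would test that.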